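The source may report more compounds than this note shows. Statements on the series, on what has been measured and on what is new or still open speak of the compounds shown alone.

Measured compounds:
Compound 1 `CCCCCCOS(=O)(=O)NC(=O)Nc1c(C(C)C)cccc1C(C)C` – 27000 nM
Compound 2 `CC(C)(C)c1cccc(C(C)(C)C)c1OC(=O)NS(=O)(=O)Nc1ccccc1` – 19000 nM

In an assay on liver for inhibition of sterol O-acyltransferase 1 (Rattus norvegicus), using microsomes (a lower number here means a stronger inhibitor, a higher number a weaker inhibitor), compound 2 holds the lowest of these two numbers, and compound 1 gives a number within the scatter of it, so the two are not separated. Compound 3 `Cc1cc(C(C)(C)C)c(OC(=O)NS(=O)(=O)Nc2ccccc2)c(C(C)(C)C)c1` differs from compound 2 by methyl in place of hydrogen on an aromatic carbon, a methyl in place of hydrogen on an aromatic carbon. Among the compounds with values here, no step between measured compounds that differ in one place is known, so there is nothing to gauge the change against. A single methyl on a remote aromatic position is expected to move this assay little, if at all beyond the scatter, in either direction. Compound 3 is therefore expected to give 15000 nM (range 5000 nM to 45000 nM), a step of a 1.3-fold lower number from compound 2 to compound 3 (0.10 log units; within the scatter) as estimated.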

Compound 3, half-maximal inhibitory concentration: 23400 nM
For compound 3 the middle estimate is 1.6-fold (0.19 log units) below the measured one; measured number inside the range.
By their numbers in this assay, from the lowest: compounds 2, 3 and 1 (each within the scatter of the next).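

In this assay, within the data shown here, methyl in place of hydrogen on the aromatic carbon para to a large group and meta to two tert-butyl groups gives a 1.2-fold higher number from compound 2 to compound 3 (0.09 log units; within the scatter), the first step on this core that can be read. This position therefore accepts the added methyl without separating compound 3 from compound 2. Nothing available explains this outcome.

Going by these compounds, whether a longer chain, an amine or a carboxylic acid at this same position would move the number beyond the scatter stays open.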